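Replacing the Ring on the Amide Nitrogen: Expected Solubility

A few compounds are considered here, and "the series" means these few. Any claim that something is new, unique, unknown or untested is made for them only; others in the source may bear on it.

Of the compounds shown here, three have so far been measured in a physicochemical assay for solubility, read by turbidimetry, measured as kinetic solubility, at pH 7.4; a lower number here means a less soluble compound, a higher number a more soluble compound. Compound 1 `O=C(NCCCCn1cccn1)c1cccc(C2SCC(=O)N2c2ccccn2)c1` gives 50000 nM, compound 3 `Cc1ccnc(N2C(=O)CSC2c2cccc(C(=O)NCCCCn3cccn3)c2)c1` gives 50000 nM, and compound 2 `O=C(NCCCCc1ccccc1)c1cccc(C2SCC(=O)N2c2ccccn2)c1` gives 20000 nM, the lowest of the three numbers. Exchanging the ring at the end of the chain gave a 2.5-fold lower number from compound 1 to compound 2 (0.40 log units; beyond the scatter), whereas adding a methyl gave no change at the digits printed from compound 1 to compound 3 (within the scatter). Compound 4 `CC(F)(F)c1cccc(N2C(=O)CSC2c2cccc(C(=O)NCCCCc3ccccc3)c2)c1` differs from compound 2 in that (a group of 10 heavy atoms (8 carbon, 2 fluorine; one six-membered aromatic ring of carbon only) in place of a group of 6 heavy atoms (5 carbon, 1 nitrogen; one six-membered aromatic ring with 1 hetero atom), on an amide-type nitrogen in a ring). For the measured compounds named here, no measured step touches this position, so the only guide is the step from compound 1 to compound 2, where phenyl in place of 1H-pyrazol-1-yl lowered the number. A modest decrease of similar size is therefore expected: a 2.9-fold lower number from compound 2 to compound 4 (0.46 log units; beyond the scatter). For compound 4 the estimated value is 7000 nM, within a range from 2000 nM to 20000 nM.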

Compound 4, solubility: 2000 nM
Beside the measured number, compound 4's estimate is 3.5-fold (0.54 log units) above it; the measured number falls inside the stated range.
By their numbers in this assay, from the lowest: compound 4; then compound 2; then compounds 1 and 3 (each within the scatter of the next).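

The ring on the amide-type nitrogen can move the solubility number strongly: replacing pyridin-2-yl with the larger fluorine-bearing group gives a 10-fold lower number from compound 2 to compound 4 (1.00 log units; beyond the scatter), whereas adding a methyl to that pyridine ring gave no change at the digits printed from compound 1 to compound 3 (within the scatter). Among the steps shown, this exchange has a larger effect on the number than the one at the end of the chain, a 2.5-fold lower number from compound 1 to compound 2 (0.40 log units; beyond the scatter). No measurement here explains the drop.

The compounds shown do not separate losing the ring nitrogen from gaining the fluorine-bearing group. Going by these compounds, how an unsubstituted phenyl, or a ring bearing a carboxylic acid, would read at this position remains open.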